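The source may report more compounds than this note shows. Statements on the series, on what has been measured and on what is new or still open speak of the compounds shown alone.

Compound 1 `O=C(COc1ccc(CN2CC=C(c3c[nH]c4cccc(F)c34)CC2)c(F)c1)NO`: 5560 nM
Compound 2 `O=C(COc1ccc(CNC2CC=C(c3c[nH]c4ccc(F)cc34)CC2)c(F)c1)NO`: 179 nM

Both numbers come from a functional assay on SW480 cells (Homo sapiens) for antiproliferative activity, with a stated time of 72 h; a higher number here means a weaker inhibitor, a lower number a stronger inhibitor. Compound 2, at 179 nM, has the lower of the two numbers and is therefore the stronger inhibitor, and its gap to compound 1 lies beyond the usual scatter. These two compounds differ in more than one place, so that gap cannot be tied to any single change.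

Compound 3 `Cc1[nH]c2ccccc2c1C1=CCC(NCc2ccc(OCC(=O)NO)cc2F)CC1` is compound 2 with 2-methyl-1H-indol-3-yl in place of 5-fluoro-1H-indol-3-yl on a double-bonded ring carbon. Within the data shown here, no measured pair tests this swap on its own, so the expectation is cautious. In this assay, a step within the scatter is expected, leaning towards a higher number. The estimated change is a 1.7-fold higher number from compound 2 to compound 3 (0.22 log units; within the scatter). Compound 3 is expected at 300 nM, with an estimated range of 100 nM to 900 nM.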

Compound 3, half-maximal inhibitory concentration: 170 nM
For compound 3 the middle estimate is 1.8-fold (0.25 log units) above the measured one, within the range that was stated.
By their numbers in this assay, from the lowest: compounds 3 and 2 (each within the scatter of the next); then compound 1.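

In this assay, replacing 5-fluoro-1H-indol-3-yl with 2-methyl-1H-indol-3-yl on the double-bonded ring carbon gives a 1.1-fold lower number from compound 2 to compound 3 (0.02 log units; within the scatter), so this position accepts either group without a readable difference. The fluorine is therefore not needed to keep compound 3 level with compound 2, at least when a methyl group is present on the indole instead. Nothing measured here accounts for why these two groups read alike.

On these data alone, how far this acceptance reaches remains open: a plain 1H-indol-3-yl with neither group, or an indole carrying an amine or a carboxylic acid, could test it. The large gap between compound 1 and compound 2 also remains unassigned, since those two compounds differ in more than one place.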